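Series notes: phenoxy in place of 3-acetylpropoxy

The compounds below may be only part of what the source reports. "The series", "measured", "known", "first", "only" and "open" are said of these compounds alone.

Three measured compounds share one core and differ only in the group on the oxygen bound to the amide-type nitrogen in the ring. Compound 1 `CCOCCON1C(=O)[C@@H](NC(=O)OCCCCC2CCCCC2)[C@@H]1C` gives 187 nM in an assay on HEK293 cells for inhibition of N-acylethanolamine-hydrolyzing acid amidase (Homo sapiens), read by fluorescence, with stated times of 10 min and 50 min; on this read-out higher numbers stand for weaker inhibition and lower numbers for stronger inhibition. Compound 2 `CSCCCON1C(=O)[C@@H](NC(=O)OCCCCC2CCCCC2)[C@@H]1C` gives 167 nM. Compound 3 `CC(=O)CCCON1C(=O)[C@@H](NC(=O)OCCCCC2CCCCC2)[C@@H]1C` gives 75 nM, the lowest number of the three. The steps of a 2.5-fold lower number from compound 1 to compound 3 (0.40 log units; beyond the scatter) and a 2.2-fold lower number from compound 2 to compound 3 (0.35 log units; beyond the scatter) are both modest, whereas a 1.1-fold lower number from compound 1 to compound 2 (0.05 log units; within the scatter) lies within the scatter. Compound 4 `C[C@H]1[C@H](NC(=O)OCCCCC2CCCCC2)C(=O)N1Oc1ccccc1` carries phenyl in place of 3-acetylpropyl on an oxygen. For the measured compounds named here, no measured step swaps the chain for a ring, so the change is only loosely bracketed: compound 1 and compound 2, which lack the acetyl end, sit modestly higher than compound 3, and a return to about that level is expected, an expected step of a 2.3-fold higher number from compound 3 to compound 4 (0.36 log units; beyond the scatter). Compound 4 is therefore estimated at 170 nM, with a range from 60 nM to 500 nM.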

Compound 4, half-maximal inhibitory concentration: 23 nM
Compound 4: middle estimate off by 7.4-fold (0.87 log units), on the high side; the whole stated range lies above it.
By their numbers in this assay, from the lowest: compound 4; then compound 3; then compounds 2 and 1 (each within the scatter of the next).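

On the oxygen bound to the amide-type nitrogen in the ring, phenyl gives the lowest number of the four in this assay (a 3.3-fold lower number from compound 3 to compound 4 (0.51 log units; beyond the scatter); a 7.3-fold lower number from compound 2 to compound 4 (0.86 log units; beyond the scatter); an 8.1-fold lower number from compound 1 to compound 4 (0.91 log units; beyond the scatter)). The earlier compounds shown here carried only open chains here; compound 4 shows that a six-membered aromatic ring of carbon only is accepted at this position and that a low number does not need the acetyl end of compound 3. Nothing available accounts for the drop.

Open, as far as these compounds go, is whether benzyl or cyclohexyl on the same oxygen would keep the number as low, and so whether the aromatic ring itself matters or any ring would do.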